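Compound 3: aryl sulfonamide replacing the methyl sulfonamide

The compounds below may be only part of what the source reports. "The series", "measured", "known", "first", "only" and "open" are said of these compounds alone.

Compound 1 `COc1ccc(-c2c(C)nc3c(N4CC[C@@H](NC(=O)OC5CCCCC5)C4)cc(C)nn23)cc1OC` and compound 2 `COc1ccc(-c2c(C)nc3c(N4CC[C@@H](NS(C)(=O)=O)C4)cc(C)nn23)cc1OC` are the measured reference points. In an ADME assay on microsomes from liver (Homo sapiens) for metabolic stability, read by LC-MS, with NADPH named in the record, with a stated time of 60 min, tested at 1 uM, in the absence of a further agent (a lower number here means that less of the compound is left, a higher number that more of the compound is left), compound 1 gives > 95%, which is a limit. In this assay compound 2 gives > 95%, also a limit. Compound 2 therefore has no exact value, and the limit of > 95% in this assay, at which 2 of the 2 values shown sit, covers all the data so far.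

Compound 3 `COc1ccc(-c2c(C)nc3c(N4CC[C@@H](NS(=O)(=O)c5ccc(NC(C)=O)cc5)C4)cc(C)nn23)cc1OC` differs from compound 2 by 4-acetamidophenyl in place of methyl on a sulfonyl sulfur.

Among the measured compounds shown here, the only measured step bearing on this change is a step that the two limits leave unreadable from compound 1 to compound 2, with methylsulfonyl in place of cyclohexyloxycarbonyl on an amine nitrogen. It gives no size to carry over. Both substituents on that nitrogen end at the same limit, so no shift beyond the scatter is expected, and any small shift is expected to be downward. The expected change is a number at least 3 percentage points lower from compound 2 to compound 3 (that floor lies within the scatter). For compound 3 the estimate in this assay is 92%, with an expected range of 75% to 100%.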

Compound 3, percent of the compound remaining: > 95%
Compound 3: only a limit was reported; the forecaster's own chance of this, stated with the estimate: 55%; middle value at least 3 percentage points away from the limit.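

The step from compound 2 to compound 3 cannot be read, and neither can the earlier step from compound 1 to compound 2, because all three compounds end at the same limit: the limit of > 95% in this assay, at which 3 of the 3 values shown sit.

The compounds shown leave open whether 4-acetamidophenyl and methyl on the sulfonyl sulfur differ at all in this assay.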